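Swapping the Piperidine Substituent in a Serotonin Receptor Series

The compounds below may be only part of what the source reports. "The series", "measured", "known", "first", "only" and "open" are said of these compounds alone.

Compound 1 `O=S(=O)(c1ccc2cc[nH]c2c1)N1CCC[C@@H]1CCN1CCC(c2c[nH]c3ccccc23)CC1` gives 0.676 nM in an assay on HEK293 cells for binding affinity to 5-hydroxytryptamine receptor 7 (Homo sapiens), read by radioligand binding; a lower number here means a stronger inhibitor, a higher number a weaker inhibitor. Compound 2 `O=c1oc2ccccc2n1C1CCN(CC[C@H]2CCCN2S(=O)(=O)c2ccc3cc[nH]c3c2)CC1` gives 1.82 nM in this assay.

Compound 2 stands highest of the two numbers; its nearest neighbour is compound 1, with a 2.7-fold higher number from compound 1 to compound 2 (0.43 log units; beyond the scatter). Compound 3 `O=C(c1ccc(F)cc1)C1CCN(CC[C@H]2CCCN2S(=O)(=O)c2ccc3cc[nH]c3c2)CC1` differs from compound 2 in that (a group of 9 heavy atoms (7 carbon, 1 oxygen, 1 fluorine; one six-membered aromatic ring of carbon only) in place of a group of 10 heavy atoms (7 carbon, 1 nitrogen, 2 oxygen; one five-membered aromatic ring with 2 hetero atoms, one six-membered aromatic ring of carbon only), on a saturated ring carbon). Going by the values given here, the only measured step that bears on this position is a 2.7-fold higher number from compound 1 to compound 2 (0.43 log units; beyond the scatter), a modest shift from exchanging the group on the same saturated ring carbon. A step of similar modest size, or none beyond the scatter, is therefore expected for a 1.6-fold higher number from compound 2 to compound 3 (0.22 log units; within the scatter). Compound 3 is estimated at 3 nM, expected to lie between 0.8 nM and 12 nM.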

Compound 3, inhibition constant: 0.832 nM
Beside the measured number, compound 3's estimate is 3.6-fold (0.56 log units) above it, within the range that was stated.
By their numbers in this assay, from the lowest: compounds 1 and 3 (each within the scatter of the next); then compound 2.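

At this saturated ring carbon, in this assay, (4-fluorophenyl)carbonyl gives a 2.2-fold lower number from compound 2 to compound 3 (0.34 log units; beyond the scatter), while a 1.2-fold higher number from compound 1 to compound 3 (0.09 log units; within the scatter) stays within the scatter. The position therefore accepts a group with one six-membered aromatic ring joined through a carbonyl as well as it accepts the two-ring 1H-indol-3-yl, and compound 2 is the one that stands apart. No measurement here explains why these groups differ. Still open, on these data alone, is whether the fluorine or the carbonyl carries the result, which an unsubstituted benzoyl group or a simple amine at this carbon could test.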